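A few compounds are considered here, and "the series" means these few. Any claim that something is new, unique, unknown or untested is made for them only; others in the source may bear on it.

Measured so far in a functional assay on HCT-116 cells (Homo sapiens) for antiproliferative activity, read by MTT assay, with a stated time of 48 h; on this read-out higher numbers stand for weaker inhibition and lower numbers for stronger inhibition:

compound 1 `Cc1cccc(-n2nncc2CN2C(=O)C3(C(C#N)=C(N)Oc4c3c3nc5ccccc5nc3c3ccccc43)c3ccccc32)c1` — a limit only, > 50000 nM
compound 2 `CCOc1ccccc1-n1nncc1CN1C(=O)C2(C(C#N)=C(N)Oc3c2c2nc4ccccc4nc2c2ccccc32)c2ccccc21` — a limit only, > 50000 nM
compound 3 `N#CC1=C(N)Oc2c(N)cc3nc4ccccc4nc3c2C12C(=O)N(Cc1cnnn1-c1ccccc1Cl)c1ccccc12` — a limit only, > 50000 nM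

All three measured values in this assay sit at the same limit (the limit of > 50000 nM in this assay, at which 3 of the 3 values shown sit), so no number is known for any of them. Compound 3 therefore stands at the limit, neither stronger nor weaker than the other two on the numbers shown. Among the compounds with values here, the single measured step, a step that the two limits leave unreadable from compound 1 to compound 2, is unreadable because both of its ends sit at the limit (the limit of > 50000 nM in this assay, at which 3 of the 3 values shown sit).

Compound 4 `Cc1ccc(-n2nncc2CN2C(=O)C3(C(C#N)=C(N)Oc4c(N)cc5nc6ccccc6nc5c43)c3ccccc32)cc1Cl` differs from compound 3 by 3-chloro-4-methylphenyl in place of 2-chlorophenyl on an aromatic nitrogen. Within the data shown here, no measured step bears on this change: the one step that was measured is unreadable, and it touches a different pair of groups on the same aromatic nitrogen. With all three measured values at the limit, the expectation for compound 4 rests on that limit alone. Compound 4 is expected to give about 70000 nM in this assay, within a range from 25000 nM to 300000 nM. The step that the limit leaves unreadable from compound 3 to compound 4 is expected to be none beyond the scatter, and most likely the assay will again report only a limit.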

Compound 4, half-maximal inhibitory concentration: > 50000 nM
Compound 4: no number, only a limit (the forecaster's own chance of this, stated with the estimate: 80%); the middle value is on the limit's open side.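

No new step can be read from compound 3 to compound 4, as each gives only a limit and not a number: the limit of > 50000 nM in this assay, at which 4 of the 4 values shown sit.

The compounds shown leave open whether this assay returns an actual number for any phenyl group on this aromatic nitrogen.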